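Trimming a Side Chain: From Compound 1 to Compound 3

This account rests on a few compounds, and the source may have more. Where it says the series, first, only, none or still open, it means among the compounds named here.

Compound 1 `CCC(C)n1cnc2c(NCc3ccc(C(=O)Nc4ccccc4N)cc3)nc(Cl)nc21` gives 75.1% in a functional assay on HCT-116 cells (Homo sapiens) for antiproliferative activity, read by CCK-8 assay, with a stated time of 72 h, tested at 8 uM (on this read-out higher numbers stand for a stronger effect at the one concentration tested and lower numbers for a weaker effect), the higher of the two numbers recorded. Compound 2 `CC(C)n1cnc2c(Nc3ccccc3)nc(NCOCc3ccc(/C=C/C(=O)Nc4ccccc4N)cc3)nc21` gives 41.7% in this assay, which lies beyond the scatter below compound 1. Compound 3 `CC(C)n1cnc2c(NCc3ccc(C(=O)Nc4ccccc4N)cc3)nc(Cl)nc21` differs from compound 1 in one place only: hydrogen in place of methyl on a saturated chain carbon, two bonds along the chain from an aromatic nitrogen. For the measured compounds named here, no step between measured compounds is recorded, so the size of this step in this assay can only be expected; with methyl replaced by hydrogen, it is expected to be none beyond the scatter. Compound 3 is therefore estimated at 70%, between 50% and 88%, an expected step of a number 5.1 percentage points lower from compound 1 to compound 3 (within the scatter).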

Compound 3, a percentage reported as inhibition, at one concentration (the size of the read-out at that concentration, not a potency): 76%
Compound 3: the middle estimate sits 6 percentage points below what was measured, within the range that was stated.
By their numbers in this assay, from the lowest: compound 2; then compounds 1 and 3 (each within the scatter of the next).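

For the compounds shown here, the exchange of sec-butyl for isopropyl amounts to a number 0.9 percentage points higher from compound 1 to compound 3 (within the scatter) in this assay, the only step measured at this position. On this read-out, hydrogen and methyl at this saturated chain carbon therefore cannot be told apart, so the position accepts this trimming with no change beyond the scatter. No available evidence accounts for this result. On these data alone, whether a longer chain such as n-hexyl, a cyclopentyl ring or a hydroxyl group would be accepted here remains open. As far as these compounds go, with one concentration tested, any difference in potency between compound 1 and compound 3 also remains open.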